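This account rests on a few compounds, and the source may have more. Where it says the series, first, only, none or still open, it means among the compounds named here.

Compound 1 `O=C(CN1CCCC1)N1CCC(NS(=O)(=O)c2cc(S(=O)(=O)c3ccccc3)ccc2C(F)(F)F)CC1` and compound 2 `CC(C)(C)C(=O)N1CCC[C@H]1C(=O)N1CCC(NS(=O)(=O)c2cc(S(=O)(=O)c3ccccc3)ccc2C(F)(F)F)CC1` share one core and differ only in the group attached to a carbonyl carbon. Among the compounds with values here, in a physicochemical assay for solubility (a higher number here means a more soluble compound, a lower number a less soluble compound), compound 1 gives 25000 nM, the lower of the two numbers so far, and compound 2 gives 50000 nM; the step of a 2.0-fold higher number from compound 1 to compound 2 (0.30 log units; within the scatter) is within the scatter, so the two compounds do not separate. Compound 3 `CCNC(=O)N1CCC[C@H]1C(=O)N1CCC(NS(=O)(=O)c2cc(S(=O)(=O)c3ccccc3)ccc2C(F)(F)F)CC1` has not yet been measured. It differs from compound 1 by 1-(ethylcarbamoyl)pyrrolidin-2-yl in place of (pyrrolidin-1-yl)methyl on a carbonyl carbon. Within the data shown here, the only measured step that bears on this change is a 2.0-fold higher number from compound 1 to compound 2 (0.30 log units; within the scatter), a swap at the same carbonyl carbon, and it stayed within the scatter. The expectation is therefore a step of a 1.6-fold higher number from compound 1 to compound 3 (0.20 log units; within the scatter) that also stays within the scatter, with no direction claimed. Compound 3 is estimated at 40000 nM, within a range from 15000 nM to 110000 nM.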

Compound 3, solubility: 100000 nM
The estimate for compound 3 lay 2.5-fold (0.40 log units) below the measured number; the range from low to high includes it.
By their numbers in this assay, from the lowest: compounds 1, 2 and 3 (each within the scatter of the next, the first and the last beyond it).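

Within the data shown here, at this carbonyl carbon, 1-(ethylcarbamoyl)pyrrolidin-2-yl in place of (pyrrolidin-1-yl)methyl gives the first step in this assay that clears the scatter, a 4.0-fold higher number from compound 1 to compound 3 (0.60 log units; beyond the scatter), so a change at this position can shift the number, though only modestly. Ethylamino in place of tert-butyl gives a 2.0-fold higher number from compound 2 to compound 3 (0.30 log units; within the scatter), which does not separate those two compounds, so only compound 1 and compound 3 stand apart. Nothing available explains the difference between compound 1 and compound 3.

The entering group differs from the leaving one in several ways at once, including its size, an added carbonyl and a hydrogen-bond donor, so the compounds shown cannot say which of these matters. A dimethylamino group in place of ethylamino, which would remove the amide hydrogen, remains an open comparison.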